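The source may report more compounds than this note shows. Statements on the series, on what has been measured and on what is new or still open speak of the compounds shown alone.

Of the compounds shown here, three have been read in a functional assay on COLO 205 cells (Homo sapiens) for inhibition, read by MTT assay, with a stated time of 48 h (a higher number here means a weaker inhibitor, a lower number a stronger inhibitor), and compound 1, `COc1cccc(/C=C/C(=O)c2cc(OC)c(OC)c(OC)c2)c1OC`, stands lowest among those with a number, giving 13200 nM. Compound 2, `COc1cc(C(=O)/C=C/c2ccc(N(C)C)cc2)cc(OC)c1OC`, gives 75000 nM, so the gap between the two lies beyond the usual scatter of repeated measurements. Compound 3, `COc1cc(/C=C/C(=O)c2cc(OC)c(OC)c(OC)c2)ccc1O`, has no number at all, and its > 100000 nM is a limit of this assay.

The next compound to be measured is compound 4, `COc1cccc(/C=C/C(=O)c2cc(OC)c(OC)c(OC)c2)c1O`. It departs from compound 1 in one place, with hydrogen in place of methyl on an oxygen on an aromatic ring, a change from methoxy to hydroxy: hydrogen in place of methyl on an oxygen on an aromatic ring.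

Among the measured compounds shown here, no measured pair in this small set shows this change directly, so any expectation rests on thin evidence. The nearest guide is compound 3, which also carries a hydroxy on an aromatic ring and sits at the limit of > 100000 nM. On that single precedent, a move towards a higher number, meaning a weaker inhibitor, is expected, and the expected size of the change is a 2.3-fold higher number from compound 1 to compound 4 (0.36 log units; beyond the scatter). A reading at the limit of the assay would not be a surprise. For compound 4 the estimated value is 30000 nM, with an expected range from 7000 nM to 100000 nM.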

Compound 4, half-maximal inhibitory concentration: 13000 nM
The estimate for compound 4 lay 2.3-fold (0.36 log units) above the measured number; the range from low to high includes it.
By their numbers in this assay, from the lowest: compounds 4 and 1 (each within the scatter of the next); then compound 2. At a limit, above all of these: compound 3.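

In this assay, among the compounds shown here, the change from methoxy to hydroxy gives a 1.0-fold lower number from compound 1 to compound 4 (0.01 log units; within the scatter), the first direct reading of this change in the set, and at this oxygen on an aromatic ring, hydrogen in place of methyl leaves the two compounds within the scatter of each other. Compound 4 thus shows that a hydroxy on an aromatic ring does not in itself bring a compound to the limit of the assay, something compound 3 could not settle, as it differs from compound 1 in more than one place. The values shown offer no measured reason for this flat step.

On these data alone, whether an ethyl group on this same oxygen, or an amine or a carboxylic acid in place of the hydroxy, would shift the number remains open, as does whether the change from methoxy to hydroxy would read the same on the other methoxy groups of the core. Steps linking compound 2 or compound 3 to the other compounds cannot be read, so the set says nothing yet about how those differences act on their own.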